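A Pyrrole Replaces the Chlorophenyl at the Imine Carbon

This account rests on a few compounds, and the source may have more. Where it says the series, first, only, none or still open, it means among the compounds named here.

Compound 1 `COc1ccc(/C=N/NC(=S)NC(C)(C)[C@H]2CC=C(C)CC2)cc1` gives 30700 nM in a functional assay on K562 cells (Homo sapiens) for inhibition, read by sulforhodamine B assay, with a stated time of 48 h; a higher number here means a weaker inhibitor of growth, a lower number a stronger inhibitor of growth.
Compound 2 `CC1=CC[C@H](C(C)(C)NC(=S)N/N=C/c2ccc(O)cc2)CC1` gives > 100000 nM in this assay, which is a limit of the assay rather than a number.
Compound 3 `CC1=CC[C@H](C(C)(C)NC(=S)N/N=C/c2cccc(Cl)c2)CC1` gives > 100000 nM in this assay, again a limit rather than a number.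

Compound 3 thus sits at the limit, where two of the three values shown sit (the limit of > 100000 nM in this assay, at which 2 of the 3 values shown sit). Compound 4 `CC1=CC[C@H](C(C)(C)NC(=S)N/N=C/c2ccc[nH]2)CC1` differs from it by 1H-pyrrol-2-yl in place of 3-chlorophenyl on a carbon with a double bond to nitrogen. Going by the values given here, the one readable step at that position, an at least 3.2-fold higher number from compound 1 to compound 3 (0.51 log units; beyond the scatter), moved the number upward, while a step that the two limits leave unreadable from compound 2 to compound 3 cannot be sized from two limits. Nothing measured shows a change at this position bringing the number back down, so compound 4 is expected at or near the limit, 80000 nM, within 25000 nM to 100000 nM, an estimated step of an at least 1.2-fold lower number from compound 3 to compound 4 (0.09 log units; that floor lies within the scatter) of little size.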

Compound 4, concentration for total growth inhibition: > 100000 nM
Compound 4: no number, only a limit; the forecaster's own chance of this, stated with the estimate: 60%; middle value at least 1.2-fold (0.09 log units) away from the limit.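

Putting 1H-pyrrol-2-yl in place of 4-methoxyphenyl gives an at least 3.2-fold higher number from compound 1 to compound 4 (0.51 log units; beyond the scatter), so a five-membered aromatic ring also falls short of compound 1, as the two other six-membered rings did. Compound 4 gives only a limit, and so do compounds 2 and 3, so the steps among these three cannot be read. Of the groups on this carbon, 4-methoxyphenyl remains the only one with a readable number: the limit of > 100000 nM in this assay, at which 3 of the 4 values shown sit.

Going by these compounds, it remains open whether an amine or a carboxylic acid on this carbon would give a readable number. A longer chain on the oxygen of 4-methoxyphenyl is equally untested here.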